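This account rests on a few compounds, and the source may have more. Where it says the series, first, only, none or still open, it means among the compounds named here.

Measured in a functional assay on THP-1 cells (Homo sapiens) for cytotoxicity, read by MTT assay, with a stated time of 24 h; on this read-out higher numbers stand for weaker inhibition and lower numbers for stronger inhibition:
- compound 1 `CCCCCCCCCCn1cc(-c2nc3ccccc3cc2C)nn1` gives a limit, > 100 ug/mL.
- compound 2 `CCCCCCCCCCn1cc(-c2nc3ccccc3cc2CCCC)nn1` gives a limit, > 100 ug/mL.
- compound 3 `CCCCCc1cc2ccccc2nc1-c1cn(-c2ccc(F)cc2)nn1` gives a limit, > 100 ug/mL.

All three values sit at the limit of > 100 ug/mL in this assay, at which 3 of the 3 values shown sit. The change from compound 2 to compound 1 is hydrogen in place of propyl on a saturated chain carbon bound to an aromatic carbon, and its step is a step that the two limits leave unreadable from compound 2 to compound 1. The difference between the core of compound 2 and the core of compound 3 is not broken down here.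

Compound 4 `CCc1cc2ccccc2nc1-c1cn(-c2ccc(F)cc2)nn1` is not yet measured. It differs from compound 3 by hydrogen in place of propyl on a saturated chain carbon, two bonds along the chain from an aromatic carbon. This is the same kind of change as that from compound 2 to compound 1, not the same: there the place was on a saturated chain carbon bound to an aromatic carbon, here it is two bonds along the chain from an aromatic carbon. The step that the limit leaves unreadable from compound 3 to compound 4 is expected to be small, since the measured pair at the limit of > 100 ug/mL in this assay, at which 3 of the 3 values shown sit, gives no readable size. Compound 4 is expected to give about 150 ug/mL, estimated between 60 ug/mL and 400 ug/mL.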

Compound 4, half-maximal inhibitory concentration: > 100 ug/mL
Compound 4 ended at the assay's limit; the forecaster's own chance of this, stated with the estimate: 85%; the middle value does not contradict the limit.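

No step from compound 3 to compound 4 can be read in this assay, because both compounds give only a limit: the limit of > 100 ug/mL in this assay, at which 4 of the 4 values shown sit.

The compounds shown leave open whether any change to the chains or the core would give a measurable value rather than a limit.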